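Ring substituents on the amine-bound phenyl of compound 2

The compounds below may be only part of what the source reports. "The series", "measured", "known", "first", "only" and "open" are said of these compounds alone.

Within the data shown here, compound 2 `CN(CCCn1c(=O)oc2ccccc21)Cc1ccccc1` gives 223 nM in an assay on membranes from liver for displacement of a labelled ligand from Sigma non-opioid intracellular receptor 1 (Rattus norvegicus), read by scintillation counting (a lower number here means a stronger inhibitor, a higher number a weaker inhibitor), and so stands as the lower of the two numbers measured so far; its nearest neighbour is compound 1 `CN(CCCn1c(=O)oc2ccccc21)Cc1cccc(Cl)c1`, which in this assay gives 3230 nM. Among the measured compounds shown here, the only step measured to date is a 14-fold lower number from compound 1 to compound 2 (1.16 log units; beyond the scatter), a large one, showing that a single substituent on this ring can move the number considerably. Compound 3 `Cc1ccc(CN(C)CCCn2c(=O)oc3ccccc32)c(C)c1` carries 2,4-dimethylphenyl in place of phenyl on a saturated chain carbon bound to an amine nitrogen. For the measured compounds named here, no measured step involves methyl on this ring, so the step between compound 1 and compound 2 is the only guide; it shows that the unsubstituted ring has so far given the lower number, and the two methyl groups now enter a ring whose substitution has only been probed once. In this assay the move is therefore expected to go toward a higher number, though by less than the chloro step. The estimated step is a 2.7-fold higher number from compound 2 to compound 3 (0.43 log units; beyond the scatter), with wide uncertainty. Compound 3 is estimated at 600 nM in this assay, within a range of 150 nM to 3000 nM.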

Compound 3, inhibition constant: 1830 nM
For compound 3 the middle estimate is 3.1-fold (0.48 log units) below the measured one; the range from low to high includes it.
By their numbers in this assay, from the lowest: compound 2; then compounds 3 and 1 (each within the scatter of the next).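

In this assay the second substituted ring also moves away from the unsubstituted one: 2,4-dimethylphenyl in place of phenyl on this saturated chain carbon gives an 8.2-fold higher number from compound 2 to compound 3 (0.91 log units; beyond the scatter) and so, beyond the scatter, joins 3-chlorophenyl on the higher side of compound 2. Among the three compounds, phenyl therefore holds the lowest number, none goes against this, and the rise is no longer tied to chloro alone, since a ring with two methyl groups and no halogen also shows it. The two substituted rings cannot be told apart in this assay, as the comparison gives a 1.8-fold lower number from compound 1 to compound 3 (0.25 log units; within the scatter) and that step lies within the scatter, so a single chloro and two methyl groups read alike here, and no measurement at hand bears on the reason for the loss relative to phenyl.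

Going by these compounds, whether one of the two methyl groups alone carries the step, or both are needed, stays open, as a ring with a single methyl group would be required to separate them. Also open, on these data alone, is whether any group on this ring, such as fluoro, methoxy or hydroxyl, could match or improve on the bare phenyl of compound 2.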